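Methoxy added to the core of compound 1

The compounds below may be only part of what the source reports. "The series", "measured", "known", "first", "only" and "open" are said of these compounds alone.

In a functional assay on A-375 cells (Homo sapiens) for antiproliferative activity (on this read-out higher numbers stand for weaker inhibition and lower numbers for stronger inhibition), compound 1 `O=C(Nc1ccc(-c2cscn2)cc1)C1CCCN(Cc2ccc(F)c(F)c2)C1` gives 880 nM, compound 2 `O=C(Nc1ccc(-c2cscn2)cc1)C1CCCN(Cc2ccc(Cl)c(Cl)c2)C1` gives 1730 nM and compound 3 `O=C(Nc1ccc(-c2cc[nH]c2)cc1)C1CCCN(Cc2ccc(F)c(F)c2)C1` gives 1420 nM. Compound 1 therefore stands within the scatter of both neighbours and cannot be ranked apart from them. The next structure is compound 4 `COc1cc(-c2cscn2)ccc1NC(=O)C1CCCN(Cc2ccc(F)c(F)c2)C1`, with methoxy in place of hydrogen on an aromatic carbon.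

Among the measured compounds shown here, two measured steps bear on this only indirectly. Placing 3,4-dichlorophenyl for 3,4-difluorophenyl gives a 2.0-fold higher number from compound 1 to compound 2 (0.29 log units; within the scatter). Placing 1H-pyrrol-3-yl for 1,3-thiazol-4-yl gives a 1.6-fold higher number from compound 1 to compound 3 (0.21 log units; within the scatter), and this change is the closer of the two, as it lies on the same six-membered aromatic ring. Neither step adds a group at the position changed in compound 4, so the data do not show what methoxy does there. A small rise in the number is expected, without confidence that it will clear the scatter. The expected step is a 1.5-fold higher number from compound 1 to compound 4 (0.17 log units; within the scatter). For compound 4 the estimated value is 1300 nM, with an expected range of 450 nM to 3800 nM.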

Compound 4, half-maximal inhibitory concentration: 580 nM
The estimate for compound 4 lay 2.2-fold (0.35 log units) above the measured number; the measured number falls inside the stated range.
By their numbers in this assay, from the lowest: compounds 4, 1, 3 and 2 (each within the scatter of the next, the first and the last beyond it).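

Compound 4 is the only compound shown that carries a group on this aromatic carbon, ortho to a large group and meta to the 1,3-thiazol-4-yl group, whereas the earlier steps exchanged the 3,4-difluorophenyl and 1,3-thiazol-4-yl groups themselves. In this assay the change to methoxy gives a 1.5-fold lower number from compound 1 to compound 4 (0.18 log units; within the scatter), so this carbon of the core accepts methoxy without a step beyond the scatter. No supporting measurement is available to account for this result.

As far as these compounds go, one substituent gives only a limited view of this position, and whether ethoxy, hydroxy or an amine on the same carbon would give a step beyond the scatter remains open. Also open, from the compounds shown here alone, is whether methoxy here would give a similar step alongside 3,4-dichlorophenyl or 1H-pyrrol-3-yl.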